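A few compounds are considered here, and "the series" means these few. Any claim that something is new, unique, unknown or untested is made for them only; others in the source may bear on it.

Measured compounds:
- compound 1, `COc1cccc(C)c1NC(=O)CN1CCC(c2cccc[n+]2[O-])CC1`: 340 nM
- compound 2, `O=C(CN1CCC(c2cccc[n+]2[O-])CC1)Nc1cccc(Cl)c1Cl`: 180 nM

In a functional assay on HEK293 cells for agonist activity at D(4) dopamine receptor (Homo sapiens), read by FLIPR (on this read-out higher numbers stand for an effect only at larger amounts of compound and lower numbers for an effect already at smaller amounts), compound 2 gives 180 nM, the lowest of the two numbers; compound 1 gives 340 nM in this assay, and the gap between them lies within the scatter, so no order can be read from the pair. Compound 3, `Cc1cccc(C)c1NC(=O)CN1CCC(c2cccc[n+]2[O-])CC1`, is still to be measured. It differs from compound 2 in one place: 2,6-dimethylphenyl in place of 2,3-dichlorophenyl on an amide-type nitrogen. Among the compounds with values here, no step between measured compounds covers this change, so its size is not known from the data. Given that the two measured compounds sit close together in this assay, no shift beyond the scatter is expected for compound 3. The estimated step of a 1.4-fold higher number from compound 2 to compound 3 (0.14 log units; within the scatter) is therefore small and uncertain in direction. In this assay compound 3 is expected to give about 250 nM, with a range from 80 nM to 800 nM.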

Compound 3, half-maximal effective concentration: 346 nM
Beside the measured number, compound 3's estimate is 1.4-fold (0.14 log units) below it, and the stated range covers the measured number.
By their numbers in this assay, from the lowest: compounds 2, 1 and 3 (each within the scatter of the next).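

In this assay, the first replacement of the whole aryl group on the amide-type nitrogen, 2,6-dimethylphenyl in place of 2,3-dichlorophenyl, comes to a 1.9-fold higher number from compound 2 to compound 3 (0.28 log units; within the scatter), so exchanging the two chlorine atoms for carbon at this place does not separate the compounds. Compound 3 also provides a step at a single substituent: methyl in place of methoxy on an aromatic carbon comes to a 1.0-fold higher number from compound 1 to compound 3 (0.01 log units; within the scatter), leaving the two numbers practically the same. No measurement bears on why these numbers stay so close.

Going by these compounds, all three compounds keep a substituted phenyl on the amide-type nitrogen, so it remains open whether an unsubstituted phenyl, or a ring carrying an amine or a carboxylic acid, would move the number beyond the scatter. On these data alone, what a change in the shared core would do also remains open.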